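Working notes: ring swap on the shared core

The source may report more compounds than this note shows. Statements on the series, on what has been measured and on what is new or still open speak of the compounds shown alone.

Measured so far, with values from a functional assay on aorta (Rattus norvegicus, strain Wistar) for inhibition; a lower number here means a stronger inhibitor, a higher number a weaker inhibitor:
- compound 1, `CC1(C)OC(=O)C2(C(=O)O1)C(c1ccc(Cl)cc1)C(c1ccccc1)=NN2c1ccccc1`, gives 590000 nM
- compound 2, `CC1(C)OC(=O)C2(C(=O)O1)C(c1ccc(F)cc1)C(c1ccccc1)=NN2c1ccccc1`, gives 1470000 nM
- compound 3, `COc1ccc(C2C(c3ccccc3)=NN(c3ccccc3)C23C(=O)OC(C)(C)OC3=O)cc1`, gives 500000 nM

Compound 3 has the lowest of the three numbers in this assay, but its gap to compound 1 is within the scatter, so the two cannot be ordered; only compound 2 sits clearly apart, as a 2.9-fold lower number from compound 2 to compound 3 (0.47 log units; beyond the scatter) and a 2.5-fold higher number from compound 1 to compound 2 (0.40 log units; beyond the scatter) show. The step of a 1.2-fold lower number from compound 1 to compound 3 (0.07 log units; within the scatter) is within the scatter.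

Compound 4, `Cc1ccc(C2C(c3ccccc3)=NN(c3ccccc3)C23C(=O)OC(C)(C)OC3=O)o1`, carries 5-methylfuran-2-yl in place of 4-methoxyphenyl on a saturated ring carbon. Within the data shown here, none of the measured steps changes the ring itself; all three exchange one substituent on the 4-substituted phenyl while the ring stays. They show that such substituent changes move the number in this assay by modest amounts at most. A whole-ring exchange to 5-methylfuran-2-yl is outside that range of evidence, so the expectation rests on the series staying in the same weak region. The step of a 1.4-fold higher number from compound 3 to compound 4 (0.15 log units; within the scatter) is the expected outcome, with no clear direction beyond the scatter. Compound 4 is estimated at 700000 nM in this assay, between 250000 nM and 2000000 nM.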

Compound 4, half-maximal inhibitory concentration: 719000 nM
Compound 4: the middle estimate sits 1.0-fold (0.01 log units) below what was measured, and the stated range covers the measured number.
By their numbers in this assay, from the lowest: compounds 3, 1 and 4 (each within the scatter of the next); then compound 2.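

In this assay the saturated ring carbon now has evidence for the exchange of a whole ring, not only of a substituent on the 4-substituted phenyl: the steps of a 1.4-fold higher number from compound 3 to compound 4 (0.16 log units; within the scatter) and a 1.2-fold higher number from compound 1 to compound 4 (0.09 log units; within the scatter) both lie within the scatter, so 5-methylfuran-2-yl cannot be told apart from 4-methoxyphenyl or 4-chlorophenyl here. Among these compounds, the same exchange against 4-fluorophenyl gives a 2.0-fold lower number from compound 2 to compound 4 (0.31 log units; beyond the scatter) and so lies beyond the scatter, which leaves compound 2 as the one compound clearly apart from the other three and shows that a six-membered aromatic ring of carbon only is not needed at this position for a number in this range. Nothing on hand accounts for the match between the two ring types or for the separate place of compound 2.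

Still open, going by these compounds, is whether an aliphatic amine, a carboxylic acid or a longer alkyl chain in place of the aromatic ring on this carbon would keep the number in the same range or move it clearly. Also open, on these data alone, is what the methyl group of 5-methylfuran-2-yl contributes to the number in this assay on its own.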